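A few compounds are considered here, and "the series" means these few. Any claim that something is new, unique, unknown or untested is made for them only; others in the source may bear on it.

Compound 1 `CCCCCCCCNC(=O)[C@@H](NC(=O)c1ccco1)[C@@H](C)O` and compound 2 `CCCCCCCCNC(=O)[C@@H](NC(=O)c1cccs1)[C@@H](C)O` share a core and differ only in the aromatic group on the carbonyl carbon. In a functional assay on SiHa cells (Homo sapiens) for cytotoxicity, read by MTT assay, with a stated time of 48 h (on this read-out lower numbers stand for stronger inhibition and higher numbers for weaker inhibition), compound 1 gives 124000 nM, and compound 2 gives 91900 nM. For the measured compounds named here, the step of a 1.3-fold lower number from compound 1 to compound 2 (0.13 log units; within the scatter) is the only measured comparison, and it lies within the scatter. On the two numbers shown, compound 2 stands with the lowest value, but its nearest neighbour, compound 1, sits within the scatter of it, so no order between them can be read.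

Compound 3 `CCCCCCCCCCCCCCNC(=O)[C@@H](NC(=O)c1cccs1)[C@@H](C)O` is formed from compound 2 by the change (hexyl in place of hydrogen on a saturated chain carbon, eight bonds along the chain from an amide-type nitrogen). Going by the values given here, no measured step concerns a change of this kind, since the one step available swaps an aromatic ring rather than lengthening the chain. On that footing, compound 3 is expected to show a step of a 1.5-fold lower number from compound 2 to compound 3 (0.19 log units; within the scatter) in this assay, with nothing beyond the scatter anticipated. The estimate for compound 3 is therefore 60000 nM, within a range from 12000 nM to 250000 nM.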

Compound 3, half-maximal inhibitory concentration: 63000 nM
Estimate against measurement, compound 3: 1.1-fold (0.02 log units) below, and the stated range covers the measured number.
By their numbers in this assay, from the lowest: compounds 3, 2 and 1 (each within the scatter of the next).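

For the compounds shown here, compound 3 gives the first reading on a change to the saturated chain, as the earlier pair differed only in the aromatic group. In this assay, hexyl in place of hydrogen on a saturated chain carbon, eight bonds along the chain from an amide-type nitrogen, gives a 1.5-fold lower number from compound 2 to compound 3 (0.16 log units; within the scatter) and so shows no readable change at this position, even though the change adds 6 carbon atoms. Nothing available here bears on why the number responds in this way.

Going by these compounds, whether a shorter chain such as butyl, a longer chain, or a chain ending in an amine or a carboxylic acid would move the number beyond the scatter stays open. On these data alone, it is also open whether the same hexyl change would give a similar result with furan-2-yl in place of thiophen-2-yl.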